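Bromo to isopropyl on the aryl ring of compound 3

The source may hold more compounds than are shown below. What is called first, only, known or untested is meant among the compounds shown, and "the series" means these compounds.

Compound 3 `CC1=C(C(=O)OCC2CCN(C(=O)OC(C)(C)C)CC2)C(c2cccc(Br)c2)C2=C(CC(C)(C)CC2=O)N1` is the reference point. Among the measured compounds shown here, in an assay on HEK293 cells for inhibition of neurogenic locus notch homolog protein 1 (Homo sapiens), read by a luciferase reporter and resazurin assay, with a stated time of 16 h (on this read-out lower numbers stand for stronger inhibition and higher numbers for weaker inhibition), compound 3 gives 360 nM, the second highest of the three numbers so far. Its nearest neighbour is compound 2 `CC1=C(C(=O)OCC2CCN(C(=O)OC(C)(C)C)CC2)[C@H](c2cccc(Br)c2)C2=C(CC(C)(C)CC2=O)N1`, which in this assay gives 130 nM; the two share every atom and bond, and the step of a 2.8-fold higher number from compound 2 to compound 3 (0.44 log units; beyond the scatter) lies beyond the scatter, the only apparent basis being (the fact that one of compounds 2 and 3 is drawn with a defined configuration and the other without, at the place where they differ). For the measured compounds named here, the furthest is compound 1 `CC1=C(C(=O)OC2CCCCC2)C(c2cccc(C(F)(F)F)c2)C2=C(CC(C)(C)CC2=O)N1`, which in this assay gives 14700 nM; it differs from compound 3 in more than one place, so no single step is drawn between them.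

Compound 4 `CC1=C(C(=O)OCC2CCN(C(=O)OC(C)(C)C)CC2)C(c2cccc(C(C)C)c2)C2=C(CC(C)(C)CC2=O)N1` is not yet measured. It differs from compound 3 by isopropyl in place of bromo on an aromatic carbon. Going by the values given here, none of the measured steps touches this position: the one measured step concerns only the drawn configuration at the saturated ring carbon, and compound 1 changes both the ester and the aryl substituent at once. Among the compounds with values here, the expectation for this assay therefore rests on no directly comparable pair; a modest change in either direction is expected, a 1.4-fold higher number from compound 3 to compound 4 (0.14 log units; within the scatter). Compound 4 is estimated at 500 nM, with a range from 120 nM to 2500 nM.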

Compound 4, half-maximal inhibitory concentration: 3320 nM
Compound 4: middle estimate off by 6.6-fold (0.82 log units), on the low side; measured number outside the range, above it.
By their numbers in this assay, from the lowest: compound 2; then compound 3; then compound 4; then compound 1.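

Among the compounds shown here, the aryl position was not covered by any single step among the earlier compounds, and it proves sensitive. In this assay, isopropyl in place of bromo gives a 9.2-fold higher number from compound 3 to compound 4 (0.96 log units; beyond the scatter), so with the ester and the shared core held constant, 3-isopropylphenyl is clearly the weaker of the two aryl groups in this pair. The change adds heavy atoms without altering the tally of rings, hydrogen-bond donors, hydrogen-bond acceptors or net charge, and nothing on record bears on why the number rises at this position.

As far as these compounds go, a single pair cannot show whether this sensitivity extends to other replacements on the aromatic carbon, so it remains open how chloro, methyl, methoxy or a nitrile at the same place would compare with the bromo of compound 3. Also open, from the compounds shown here alone, is whether a defined configuration at the saturated ring carbon would shift the number of compound 4 as it separates compound 2 from compound 3, and whether the aryl step would hold with a cyclohexyl ester in place of the ester carried here.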